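This account rests on a few compounds, and the source may have more. Where it says the series, first, only, none or still open, it means among the compounds named here.

Three compounds have so far been tested in a functional assay on the whole organism (strain Wistar) for inhibition, with Rattus norvegicus as the target, read by paw edema, with stated times of 60 min and 24 h, at a dose of 100 mg/kg by the oral route; a higher number here means more inhibition at the dose given (going by the name of the read-out), a lower number less inhibition:

compound 1, `CCNC(=O)CC1CCc2cc(OC)c(OC)cc21`, gives 33.3%
compound 2, `COc1cc2c(cc1OC)C(CC(=O)NC(C)(C)C)CC2`, gives 40%
compound 3, `COc1cc2c(cc1OC)C(CC(=O)NC1CCCCC1)CC2`, gives 53.3%

All three share the same core and differ only in the group carried on the amide-type nitrogen. Compound 3 stands highest of the three: the step of a number 13.3 percentage points higher from compound 2 to compound 3 (beyond the scatter) and the step of a number 20 percentage points higher from compound 1 to compound 3 (beyond the scatter) both lie beyond the scatter, while the step of a number 6.7 percentage points higher from compound 1 to compound 2 (within the scatter) does not.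

Compound 4, `COc1cc2c(cc1OC)C(CC(=O)N1CCCC1)CC2`, has not yet been measured in this assay. It differs from compound 3 in one place: pyrrolidin-1-yl in place of cyclohexylamino on a carbonyl carbon. The measured steps only ever exchanged one group on the amide-type nitrogen for another while keeping its hydrogen; none of them replaced the cyclohexylamino group by a ring that closes onto the nitrogen itself. They offer a loose guide that among ethyl, tert-butyl and cyclohexyl on that nitrogen the cyclohexyl went with the most inhibition, which would argue for a smaller number here, but the change in compound 4 is of a different kind, so the direction is uncertain.

Compound 4 is expected to give about 40%, within a range of 25% to 55%, which corresponds to an estimated step of a number 13.3 percentage points lower from compound 3 to compound 4 (beyond the scatter).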

Compound 4, a percentage reported as inhibition, in the whole organism at one dose (the size of the read-out at that dose, not a potency): 33.3%
For compound 4 the middle estimate is 6.7 percentage points above the measured one; measured number inside the range.
By their numbers in this assay, from the lowest: compounds 1, 4 and 2 (each within the scatter of the next); then compound 3.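

In this assay, pyrrolidin-1-yl in place of cyclohexylamino on the carbonyl carbon removes the amide hydrogen and changes the ring in a single exchange, and the outcome is a number 20 percentage points lower from compound 3 to compound 4 (beyond the scatter). Set against the two smaller amide groups, the same ring shows a number 6.7 percentage points lower from compound 2 to compound 4 (within the scatter) and no change at the digits printed from compound 1 to compound 4 (within the scatter), so losing the amide hydrogen does not by itself take inhibition out of reach of what ethylamino and (tert-butyl)amino give, and among these four compounds only the cyclohexylamino group of compound 3 stands apart. No measurement is available that would explain these numbers.

The exchange from compound 3 to compound 4 alters two things at once, so the compounds shown cannot say whether the drop follows the missing amide hydrogen or the different ring. Piperidin-1-yl, a six-membered ring closed onto the nitrogen, and cyclopentylamino, a five-membered carbon ring that keeps the amide hydrogen, would pull those two changes apart.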